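Methoxycarbonyl to Carboxy Under an Assay Limit

This account rests on a few compounds, and the source may have more. Where it says the series, first, only, none or still open, it means among the compounds named here.

In a functional assay on SK-BR-3 cells (Homo sapiens) for antiproliferative activity, read by MTT assay, with a stated time of 72 h (on this read-out lower numbers stand for stronger inhibition and higher numbers for weaker inhibition), none of the three measured compounds gives a number. Compound 1 (`C/C=C1/[C@H](O[C@@H]2O[C@H](COC(C)=O)[C@@H](OC(C)=O)[C@H](OC(C)=O)[C@H]2OC(C)=O)OC=C(C(=O)O)[C@H]1CC(=O)O`) reads > 20000 nM here, which is a limit of the assay. Compound 2 (`C=CCOC(=O)C[C@@H]1C(C(=O)OC)=CO[C@@H](O[C@@H]2O[C@H](COC(C)=O)[C@@H](OC(C)=O)[C@H](OC(C)=O)[C@H]2OC(C)=O)/C1=C/C`) reads > 20000 nM here, also a limit. Compound 3 (`C/C=C1/[C@H](O[C@@H]2O[C@H](COC(C)=O)[C@@H](OC(C)=O)[C@H](OC(C)=O)[C@H]2OC(C)=O)OC=C(C(=O)OC)[C@H]1CC(=O)OC`) reads > 15000 nM here, again a limit, so it has only a bound to stand on, as do the two other compounds.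

Compound 4 (`C/C=C1/[C@H](O[C@@H]2O[C@H](COC(C)=O)[C@@H](OC(C)=O)[C@H](OC(C)=O)[C@H]2OC(C)=O)OC=C(C(=O)O)[C@H]1CC(=O)OC`) differs from compound 3 in one place (hydrogen in place of methyl on an oxygen next to a carbonyl group), with hydrogen in place of methyl on an oxygen next to a carbonyl group, which turns methoxycarbonyl to carboxy. Among the measured compounds shown here, the one measured step, a step that the two limits leave unreadable from compound 2 to compound 3 in size, is a different change and cannot be read. The measured values sit at the limit of > 15000 nM in this assay, at which 1 of the 3 values shown sits, and at the limit of > 20000 nM in this assay, at which 2 of the 3 values shown sit, and so give no size or direction for this change. The expectation therefore rests on compound 3, whose > 15000 nM is a limit, and no change beyond the scatter is foreseen. The estimated step that the limit leaves unreadable from compound 3 to compound 4 stays within the scatter. For compound 4 the expected value is 20000 nM with an estimated range of 10000 nM to 40000 nM and it will most likely be reported only as a limit.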

Compound 4, half-maximal inhibitory concentration: > 20000 nM
Compound 4: only a limit was reported; the forecaster's own chance of this, stated with the estimate: 85%; the middle value sits exactly at the limit.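

Compound 4 gives > 20000 nM in this assay, which is a limit of the assay. Among the compounds shown here, its steps to compound 1 and compound 3 cannot be read, so this result adds no new step. The compounds shown leave open whether methoxycarbonyl to carboxy changes the read-out at all, and what number any of the four compounds would reach.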